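Carbonyl substituent change from compound 3 to compound 4

The source may report more compounds than this note shows. Statements on the series, on what has been measured and on what is new or still open speak of the compounds shown alone.

compound 1 `CN1CCc2nc(C#Cc3ccccc3)sc2C1`: > 10000 nM
compound 2 `Fc1cccc(C#Cc2nc3c(s2)CN(C2CCOC2)CC3)c1`: 400 nM
compound 3 `O=C(C1CC1)N1CCc2nc(C#Cc3ccccc3)sc2C1`: 290 nM

In an assay on HEK293 cells for negative allosteric modulation of metabotropic glutamate receptor 5 (Homo sapiens), read by FLIPR, with a stated time of 1 h (on this read-out higher numbers stand for weaker inhibition and lower numbers for stronger inhibition), compound 1 gives > 10000 nM, which is a limit of the assay rather than a number (the limit of > 10000 nM in this assay, at which 1 of the 3 values shown sits). Compound 3, with 290 nM, holds the lower of the two numbers in this assay; compound 2, with 400 nM, lies within the scatter of it. Among the measured compounds shown here, the one step with numbers on both sides is an at least 34-fold lower number from compound 1 to compound 3 (1.53 log units; beyond the scatter).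

Compound 4 `O=C(C1CC(F)C1)N1CCc2nc(C#Cc3ccccc3)sc2C1` differs from compound 3 by 3-fluorocyclobutyl in place of cyclopropyl on a carbonyl carbon. For the measured compounds named here, no measured step alters this group on the carbonyl carbon; the step from compound 1 to compound 3 only installs the carbonyl. Hence for compound 4 the expected step is a 1.0-fold higher number from compound 3 to compound 4 (0.01 log units; within the scatter), none beyond the scatter. Compound 4 is estimated at 300 nM, range 100 nM to 900 nM.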

Compound 4, half-maximal inhibitory concentration: > 10000 nM
Compound 4: no number, only a limit; the forecaster's own chance of this, stated with the estimate: 5%; at least 33-fold (1.52 log units) between middle value and limit.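

In this assay compound 4 gives > 10000 nM, which is a limit of the assay and not a number. The carbonyl alone therefore does not secure inhibition, as the group on the carbonyl carbon also counts: 3-fluorocyclobutyl in place of cyclopropyl gives an at least 34-fold higher number from compound 3 to compound 4 (1.53 log units; beyond the scatter). The step between compound 1 and compound 4 cannot be read, since both values are limits: the limit of > 10000 nM in this assay, at which 2 of the 4 values shown sit.

Open, on these data alone, is how an unsubstituted cyclobutyl on the carbonyl carbon would read, which would separate the fluorine from the change of ring. A methyl or an isopropyl at this place would show how much of the group is needed.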